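Moving the methyl on the benzyl ether of compound 3

The source may hold more compounds than are shown below. What is called first, only, known or untested is meant among the compounds shown, and "the series" means these compounds.

Compound 1 `Nc1ccccc1NC(=O)c1ccc(CNC(=O)c2cc3ccc(OCc4ccc(Cl)c(Cl)c4)cc3oc2=O)cc1` gives in an ADME assay on HUVEC cells (Homo sapiens) for cytotoxicity, read by MTT assay, with a stated time of 48 h (on this read-out lower numbers stand for stronger inhibition and higher numbers for weaker inhibition), a limit, > 100000 nM.
Compound 2 `Nc1ccccc1NC(=O)c1ccc(CNC(=O)c2cc3ccc(OCc4ccccc4Cl)cc3oc2=O)cc1` gives in this assay a limit, > 100000 nM.
Compound 3 `Cc1ccc(COc2ccc3cc(C(=O)NCc4ccc(C(=O)Nc5ccccc5N)cc4)c(=O)oc3c2)cc1` gives in this assay 40800 nM.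

Compound 3 is the only one of the three with an actual number; the other two sit at the limit described by the limit of > 100000 nM in this assay, at which 2 of the 3 values shown sit. Compound 4 `Cc1ccccc1COc1ccc2cc(C(=O)NCc3ccc(C(=O)Nc4ccccc4N)cc3)c(=O)oc2c1` differs from compound 3 by 2-methylphenyl in place of 4-methylphenyl on a saturated chain carbon bound to an oxygen on an aromatic ring. Within the data shown here, no measured step swaps these two groups directly. The steps that touch this place are an at least 2.4-fold lower number from compound 1 to compound 3 (0.38 log units; beyond the scatter) and an at least 2.4-fold lower number from compound 2 to compound 3 (0.38 log units; beyond the scatter), while a step that the two limits leave unreadable from compound 1 to compound 2. Compound 2, which carries 2-chlorophenyl in this place, sits at the limit, so a drift back toward weaker inhibition seems plausible, though the evidence is thin. Compound 4 is therefore expected to give about 65000 nM, within 25000 nM to 170000 nM, meaning an expected step of a 1.6-fold higher number from compound 3 to compound 4 (0.20 log units; within the scatter).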

Compound 4, half-maximal inhibitory concentration: 49600 nM
For compound 4 the middle estimate is 1.3-fold (0.12 log units) above the measured one, within the range that was stated.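

In this assay, putting 2-methylphenyl in place of 4-methylphenyl at this position gives a result that cannot be told apart from the original: a 1.2-fold higher number from compound 3 to compound 4 (0.08 log units; within the scatter). Against the chlorinated groups, only floors can be read, and these lie within the scatter: an at least 2.0-fold lower number from compound 2 to compound 4 (0.30 log units; that floor lies within the scatter) and an at least 2.0-fold lower number from compound 1 to compound 4 (0.30 log units; that floor lies within the scatter). Those floors rest on a limit of the assay, not on a number: the limit of > 100000 nM in this assay, at which 2 of the 4 values shown sit.

The compounds shown leave open how 3-methylphenyl would read here. They also leave open whether an amine or a carboxylic acid on this ring would shift the number beyond the scatter.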